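Azole swap at the piperazine methylene: oxazole for imidazole

The compounds below may be only part of what the source reports. "The series", "measured", "known", "first", "only" and "open" are said of these compounds alone.

Compound 2 `Cc1nc(CN2CCN(c3cccc4[nH]c(-c5ccc(C(C)(C)C)cc5)nc34)CC2)c[nH]1` gives the lower of the two numbers in an assay on isolated protein for displacement of a labelled ligand from Gonadotropin-releasing hormone receptor (Rattus norvegicus) (on this read-out lower numbers stand for stronger inhibition and higher numbers for weaker inhibition), at 28 nM, while compound 1 `Cn1cnc(CN2CCN(c3cccc4[nH]c(-c5ccc(C(C)(C)C)cc5)nc34)CC2)c1` gives 98 nM in this assay. For the measured compounds named here, the single step so far, a 3.5-fold lower number from compound 1 to compound 2 (0.54 log units; beyond the scatter), went with the gain of a hydrogen-bond donor. Compound 3 `Cc1nc(C)c(CN2CCN(c3cccc4[nH]c(-c5ccc(C(C)(C)C)cc5)nc34)CC2)o1` carries 2,4-dimethyl-1,3-oxazol-5-yl in place of 2-methyl-1H-imidazol-4-yl on a saturated chain carbon bound to an amine nitrogen in a ring, which removes that donor again. A modest step toward weaker binding, a 3.2-fold higher number from compound 2 to compound 3 (0.51 log units; beyond the scatter), is therefore expected, because compound 1 without a donor gives 98 nM. Compound 3 is estimated at 90 nM in this assay, within 30 nM to 300 nM.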

Compound 3, half-maximal inhibitory concentration: 740 nM
For compound 3 the middle estimate is 8.2-fold (0.91 log units) below the measured one, and the stated range ends below it.
By their numbers in this assay, from the lowest: compound 2; then compound 1; then compound 3.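

In this assay the oxazole stands apart from both imidazoles, with a 26-fold higher number from compound 2 to compound 3 (1.42 log units; beyond the scatter) and a 7.6-fold higher number from compound 1 to compound 3 (0.88 log units; beyond the scatter) at the same chain carbon. Compound 1 also lacks the hydrogen-bond donor of compound 2, yet the second step remains, so loss of that donor does not cover the whole change. No data on hand account for this gap.

Still open, from the compounds shown here alone, is whether the oxazole ring or its added methyl goes with the weaker number, and how a 2-methyl-1,3-oxazol-5-yl or a pyridine would read at this carbon.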